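Thiosemicarbazone series: furan to pyrrole on the imine carbon

A few compounds are considered here, and "the series" means these few. Any claim that something is new, unique, unknown or untested is made for them only; others in the source may bear on it.

Measured so far:
- compound 1 `CC1=CC[C@H](C(C)(C)NC(=S)N/N=C/c2ccccc2)CC1` gives 22200 nM in a functional assay on HT-29 cells (Homo sapiens) for inhibition, read by sulforhodamine B assay, with a stated time of 48 h; a higher number here means a weaker inhibitor of growth, a lower number a stronger inhibitor of growth
- compound 2 `CC1=CC[C@H](C(C)(C)NC(=S)N/N=C/c2ccco2)CC1` gives 26900 nM in this assay

Compound 2 holds the highest of the two numbers in this assay; its nearest neighbour is compound 1, and the gap between the two lies within the scatter, so no order can be read from them.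

Compound 3 `CC1=CC[C@H](C(C)(C)NC(=S)N/N=C/c2ccc[nH]2)CC1` is not yet measured. It differs from compound 2 by 1H-pyrrol-2-yl in place of furan-2-yl on a carbon with a double bond to nitrogen.

Among the measured compounds shown here, the only step in hand that bears on this change is an aryl swap on the same carbon: a 1.2-fold higher number from compound 1 to compound 2 (0.08 log units; within the scatter). That swap, phenyl for furan-2-yl, left the number essentially where it was. With one such step and no other information on this position, there is nothing to suggest that exchanging furan-2-yl for 1H-pyrrol-2-yl would move the result either way, and the expected step in this assay is none beyond the scatter: a 1.0-fold higher number from compound 2 to compound 3 (0.00 log units; within the scatter).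

Compound 3 is therefore expected to give about 27000 nM in this assay, with a range of 11000 nM to 65000 nM.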

Compound 3, concentration for total growth inhibition: > 100000 nM
Compound 3: only a limit was reported; the forecaster's own chance of this, stated with the estimate: 10%; middle value at least 3.7-fold (0.56 log units) away from the limit.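

Compound 3 in this assay is reported only as a limit of the assay, > 100000 nM, not as a number. Even so, this carbon with a double bond to nitrogen does not accept every aromatic ring equally, which the phenyl and furan-2-yl pair alone could not show: the change to 1H-pyrrol-2-yl brings an at least 3.7-fold higher number from compound 2 to compound 3 (0.57 log units; beyond the scatter) and an at least 4.5-fold higher number from compound 1 to compound 3 (0.65 log units; beyond the scatter), so growth inhibition in this series is sensitive to the ring at this carbon. Furan-2-yl and 1H-pyrrol-2-yl are both five-membered aromatic rings with 1 hetero atom, and they differ in oxygen against nitrogen and in 1 hydrogen-bond acceptor against 1 hydrogen-bond donor, a difference that is counted here but not shown to be the cause.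

A pyrrole ring carrying a methyl group on its nitrogen, or a thiophene ring at the same carbon, would help to test whether the ring hydrogen on nitrogen is what matters. From the compounds shown here alone, the true size of both steps remains open, because compound 3 reads only as a limit: the limit of > 100000 nM in this assay, at which 1 of the 3 values shown sits.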